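The source may hold more compounds than are shown below. What is called first, only, known or untested is meant among the compounds shown, and "the series" means these compounds.

Measured compounds:
compound 1 `N#Cc1ncc(N2C(=O)C3(CCC3)N(c3ccc(OC4CCNCC4)nc3)C2=S)cc1C(F)(F)F` with 5.99 h
compound 2 `N#Cc1ncc(N2C(=O)C3(CCC3)N(c3ccc(OC4CCNCC4)cc3)C2=S)cc1Cl` with 3.7 h

Of the compounds shown here, two have been tested in an ADME assay on the whole organism (Mus musculus, strain CD1) for metabolic stability, at a dose of 2 mg/kg by the intravenous route; on this read-out lower numbers stand for a shorter-lived compound and higher numbers for a longer-lived compound. Compound 1 gives 5.99 h in this assay, and compound 2 gives 3.7 h. Of the two numbers, that of compound 1 is the larger, yet the gap to compound 2 lies within the usual scatter of the measurement, so the two compounds are not told apart by these data. Going by the values given here, the two also differ from each other in more than one place, so no single step between them can be read.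

Compound 3 `Cc1cc(N2C(=O)C3(CCC3)N(c3ccc(OC4CCNCC4)nc3)C2=S)cnc1C#N` has not yet been measured in this assay. It is derived from compound 1 by a single change: methyl in place of trifluoromethyl on an aromatic carbon. The rest of the shared core is kept. Among the compounds with values here, with no measured step to lean on, the size of the change is open. The account expects a modest downward step a 1.7-fold lower number from compound 1 to compound 3 (0.23 log units; within the scatter) from compound 1 to compound 3, a step that may well fall near the edge of the scatter rather than clearly beyond it. Compound 3 is thus estimated to give 3.5 h in this assay, with a likely range from 1.5 h to 8 h.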

Compound 3, half-life: 3 h
The estimate for compound 3 lay 1.2-fold (0.07 log units) above the measured number; measured number inside the range.
By their numbers in this assay, from the lowest: compounds 3, 2 and 1 (each within the scatter of the next).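

Going by these compounds alone, at this position, on an aromatic carbon ortho to a cyano group, methyl in place of trifluoromethyl gives the first single-place comparison of the series in this assay, and it reads as a 2.0-fold lower number from compound 1 to compound 3 (0.30 log units; within the scatter) in this change. The exchange of a group of 4 heavy atoms for one of 1 heavy atom, neither carrying a ring, a hydrogen-bond donor or a hydrogen-bond acceptor, therefore does not separate the two compounds on this read-out, although the step lies right at the limit of what can still count as scatter. Nothing measured here speaks to why the step has this size.

Going by these compounds, whether another group at this position, such as an ethyl chain, a methoxy group or a primary amine, would give a step beyond the scatter remains open. The chlorine that compound 2 carries on the corresponding ring cannot be read against trifluoromethyl or methyl, since compound 2 differs from both compound 1 and compound 3 in more than one place.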